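The source may hold more compounds than are shown below. What is called first, only, known or untested is meant among the compounds shown, and "the series" means these compounds.

Compound 1, `CCCCCCCCSC(=S)N[C@H]1CCOC1=O`, in a functional assay on MGC-803 cells (Homo sapiens) for cytotoxicity, read by MTT assay, with a stated time of 72 h (on this read-out higher numbers stand for weaker inhibition and lower numbers for stronger inhibition), gives only a limit, > 128000 nM.
Compound 2, `CCCCCCCCCCCCSC(=S)N[C@H]1CCOC1=O`, in this assay gives 33300 nM.

Compound 2 holds the only number shown in this assay; the other entry, that of compound 1, is a limit and not a number. Compound 3, `CCCCCCCCCCCCCCSC(=S)N[C@H]1CCOC1=O`, is not yet measured and differs from compound 2 by ethyl in place of hydrogen on a saturated chain carbon, ten or more bonds along the chain from a sulfur. Within the data shown here, the one measured step that bears on this change is of the same kind, a lengthening of the chain on its far end: an at least 3.8-fold lower number from compound 1 to compound 2 (0.58 log units; beyond the scatter). That step rested on a limit at one end, so its true size is not fixed, but it points towards stronger inhibition as the chain grows. Whether the gain continues past the chain of compound 2 cannot be read from these two compounds alone. The expectation is therefore a small further step, a 1.7-fold lower number from compound 2 to compound 3 (0.22 log units; within the scatter), smaller than the one already seen. Compound 3 is estimated at 20000 nM, with a range from 8000 nM to 60000 nM.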

Compound 3, half-maximal inhibitory concentration: 36600 nM
Compound 3: the middle estimate sits 1.8-fold (0.26 log units) below what was measured; the measured number falls inside the stated range.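

In this assay, the added ethyl on a saturated chain carbon gives a 1.1-fold higher number from compound 2 to compound 3 (0.04 log units; within the scatter) and so brings no change that can be told from the scatter. The earlier step could only suggest that lengthening the chain keeps strengthening inhibition, but here that gain does not carry on past the chain of compound 2. The longer chains still stand apart from the chain of compound 1, as an at least 3.4-fold lower number from compound 1 to compound 3 (0.54 log units; beyond the scatter) is beyond the scatter, so across these three compounds the change appears only in the first step and compound 3 does not extend it.

On these data alone, the true size of that first step stays open because compound 1 gives only a limit and not a number: the limit of > 128000 nM in this assay, at which 1 of the 3 values shown sits. Whether a still longer chain, or a chain carrying an amine or a carboxylic acid, would shift the number in this assay cannot be told from these compounds, and neither can whether the level shared by compound 2 and compound 3 would hold.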